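The compounds below may be only part of what the source reports. "The series", "measured", "known", "first", "only" and "open" are said of these compounds alone.

Two compounds from this series share one core and differ only in the group on the saturated chain carbon bound to a nitrogen on the aromatic ring. Compound 1 `O=c1nc(NCc2cccc(F)c2)oc2c([N+](=O)[O-])cc(C(F)(F)F)cc12` carries a 3-fluorophenyl there. In an ADME assay on Vero cells (Chlorocebus sabaeus) for cytotoxicity, read by MTT assay, with a stated time of 48 h (a higher number here means a weaker inhibitor, a lower number a stronger inhibitor), compound 1 reaches only a limit of the assay, > 64 ug/mL, which is the limit of > 64 ug/mL in this assay, at which 1 of the 2 values shown sits. Within the data shown here, compound 2 `O=c1nc(NCc2ccc3c(c2)OCCO3)oc2c([N+](=O)[O-])cc(C(F)(F)F)cc12` carries a 2,3-dihydro-1,4-benzodioxin-6-yl instead, and in this assay compound 2 gives 25.3 ug/mL, the only true number measured here. The step of an at least 2.5-fold lower number from compound 1 to compound 2 (0.40 log units; beyond the scatter) shows that change brought the number down.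

Compound 3 `COc1ccc(CNc2nc(=O)c3cc(C(F)(F)F)cc([N+](=O)[O-])c3o2)cc1OC` is the next variation. Its difference from compound 2 is 3,4-dimethoxyphenyl in place of 2,3-dihydro-1,4-benzodioxin-6-yl on a saturated chain carbon bound to a nitrogen on an aromatic ring. Among the measured compounds shown here, the two groups that swap match in what is counted, and no measured step mirrors this exchange, so no shift beyond the scatter is expected. For compound 3 in this assay the expected value is 25 ug/mL, between 10 ug/mL and 64 ug/mL. That estimate means an expected step of a 1.0-fold lower number from compound 2 to compound 3 (0.01 log units; within the scatter).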

Compound 3, half-maximal inhibitory concentration: 29.2 ug/mL
For compound 3 the middle estimate is 1.2-fold (0.07 log units) below the measured one; measured number inside the range.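

In this assay, swapping the closed ring of 2,3-dihydro-1,4-benzodioxin-6-yl for the two separate methoxy groups of 3,4-dimethoxyphenyl gives a 1.2-fold higher number from compound 2 to compound 3 (0.06 log units; within the scatter), so the closed ring makes no visible difference at this position. The second oxygen-bearing group also stands apart from the 3-fluorophenyl, with an at least 2.1-fold lower number from compound 1 to compound 3 (0.34 log units; beyond the scatter), and so the earlier step from compound 1 is no longer seen with just one group. Compound 1 gives a limit rather than a number, so this step is only a bound: the limit of > 64 ug/mL in this assay, at which 1 of the 3 values shown sits.

Going by these compounds, how a plain phenyl, a phenyl carrying a single methoxy group or a saturated butyl chain would behave here stays open. It also remains unclear whether the oxygens of compound 2 and compound 3 are what goes with their lower numbers.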